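The source may report more compounds than this note shows. Statements on the series, on what has been measured and on what is new or still open speak of the compounds shown alone.

Working notes on the series. In a functional assay on KB cells (Homo sapiens) for inhibition, read by MTT assay, with a stated time of 24 h, tested at 0.1 ug/mL (a higher number here means more inhibition of growth at the concentration tested, a lower number less inhibition of growth), compound 1 (`CC(=O)SCCC(CCCCC(=O)O)SC(C)=O`) gives 7.24% and compound 2 (`O=C(CCCCC(S)CCS)Nc1ccccc1`) gives 9.49% and these two values lie within the scatter of each other. Compound 3 (`CC(=O)SCCC(CCCCC(=O)Nc1cccc(Cl)c1)SC(C)=O`) replaces hydroxy with (3-chlorophenyl)amino on a carbonyl carbon of compound 1 ((3-chlorophenyl)amino in place of hydroxy on a carbonyl carbon). Within the data shown here, no measured step in this assay isolates this change. Among the measured compounds shown here, a small rise in growth inhibition, not far beyond the scatter, is expected, with compound 2 at 9.49% as the only measured compound carrying a ring. The expected size is modest (a number 5.8 percentage points higher from compound 1 to compound 3 (within the scatter)). For compound 3 the estimated value is 13% (range 3% to 30%).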

Compound 3, percent growth inhibition at one concentration: 5.72%
Compound 3: the middle estimate sits 7.3 percentage points above what was measured; the measured number falls inside the stated range.
By their numbers in this assay, from the lowest: compounds 3, 1 and 2 (each within the scatter of the next).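

With the shared core held fixed, (3-chlorophenyl)amino in place of hydroxy on a carbonyl carbon gives a number 1.5 percentage points lower from compound 1 to compound 3 (within the scatter), so this first measured step at this position shows no detectable change in growth inhibition. At this single concentration, the position accepts a six-membered aromatic ring in place of hydroxy without moving the read-out beyond the scatter. No available evidence bears on this result.

As far as these compounds go, whether a benzylamino group, a morpholine amide or a longer chain on the same carbonyl carbon would move the read-out remains open. From the compounds shown here alone, the effect of replacing the chlorine on the ring also remains open.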